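Phenoxy for 4-chlorobenzyl: notes on compound 4

This account rests on a few compounds, and the source may have more. Where it says the series, first, only, none or still open, it means among the compounds named here.

In a functional assay on the whole organism for inhibition, with Rattus norvegicus as the target (on this read-out higher numbers stand for an effect only at larger amounts of compound and lower numbers for an effect already at smaller amounts), compound 1 (`CC(C)c1ccc(OC(Cc2ccc3ccccc3c2)C(=O)O)cc1`) gives 50 mg/kg as a measured number. Compound 2 (`Cc1cc(C)c(CC(C)(Oc2ccc(C(C)C)cc2)C(=O)O)c(C)c1`) gives < 10 mg/kg as its entry, and this is a limit of the assay, not a number. Compound 3 (`CC(Cc1ccc(Cl)cc1)(Oc1ccc(Cc2ccc(Cl)cc2)cc1)C(=O)O`) gives > 10 mg/kg as its entry, which is likewise a limit. Compound 3 therefore has no exact position in the series, and compound 1 alone carries a measured number. Compound 4 (`CC(Cc1ccc(Cl)cc1)(Oc1ccc(Oc2ccccc2)cc1)C(=O)O`) has phenoxy in place of 4-chlorobenzyl on an aromatic carbon, para to a large group phenoxy in place of 4-chlorobenzyl on an aromatic carbon in the comparison with compound 3. Going by the values given here, no measured pair differs in one place, so no direct precedent exists for this change. In this assay the expected change is a step that the limit leaves unreadable from compound 3 to compound 4 and is taken as no larger than the scatter, with no direction expected. The estimate rests on the limit of compound 3 at > 10 mg/kg and on the structural change alone. Compound 4 is estimated at 20 mg/kg with an expected range of 7 mg/kg to 60 mg/kg in this series.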

Compound 4, dose for half-maximal effect: < 1 mg/kg
Compound 4 gave a limit, no number; the forecaster's own chance of this, stated with the estimate: 45%; middle value at least 20-fold (1.30 log units) from the limit.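

In this assay, phenoxy in place of 4-chlorobenzyl on an aromatic carbon, para to a large group, gives an at least 10-fold lower number from compound 3 to compound 4 (1.00 log units; beyond the scatter), so the step lies beyond the scatter. The entry of compound 4, < 1 mg/kg, is a limit of the assay, and the entry of compound 3 is also a limit. Going by these compounds alone, this is the only step between compounds that differ in one place, and it shows that the group at this position matters in this assay, which the earlier compounds, with no such pair among them, could not show.

From the compounds shown here alone, neither end of the step is a number, so its true size remains open. The compounds shown also do not separate the effect of the oxygen link from that of losing the chlorine: benzyl or 4-chlorophenoxy at the same place would separate the two.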